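The source may report more compounds than this note shows. Statements on the series, on what has been measured and on what is new or still open speak of the compounds shown alone.

Measured in a functional assay on B16-F0 cells (Mus musculus) for inhibition, read by CCK-8 assay, with a stated time of 48 h; a lower number here means a stronger inhibitor, a higher number a weaker inhibitor:
- compound 1 `COc1cc(-c2ccnc3cc(-c4ccc(F)cc4)nn23)cc(OC)c1OC`: 4540 nM
- compound 2 `COc1cc(-c2ccnc3cc(-c4ccc(C)cc4)nn23)cc(OC)c1OC`: 21 nM
- compound 3 `COc1cc(-c2ccnc3cc(-c4ccc(N(C)C)cc4)nn23)cc(OC)c1OC`: 702 nM

Compound 3 holds the middle place of the three, with a 6.5-fold lower number from compound 1 to compound 3 (0.81 log units; beyond the scatter) and a 33-fold higher number from compound 2 to compound 3 (1.52 log units; beyond the scatter). Compound 4 `COc1ccc(-c2cc3nccc(-c4cc(OC)c(OC)c(OC)c4)n3n2)cc1N` carries 3-amino-4-methoxyphenyl in place of 4-(dimethylamino)phenyl on an aromatic carbon. All three measured steps change one group on this same phenyl ring, and the largest is a 220-fold lower number from compound 1 to compound 2 (2.33 log units; beyond the scatter). Within the data shown here, no measured compound tests the entering amino or methoxy group directly. Loss of dimethylamino may recover part of a 33-fold higher number from compound 2 to compound 3 (1.52 log units; beyond the scatter), so a large step to a lower number is expected in this assay. The expected change is an 18-fold lower number from compound 3 to compound 4 (1.24 log units; beyond the scatter). For compound 4 the estimate is 40 nM, within an expected range of 8 nM to 300 nM.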

Compound 4, half-maximal inhibitory concentration: 88 nM
Beside the measured number, compound 4's estimate is 2.2-fold (0.34 log units) below it, within the range that was stated.
By their numbers in this assay, from the lowest: compound 2; then compound 4; then compound 3; then compound 1.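

In this assay, 3-amino-4-methoxyphenyl at this position shows that a phenyl ring carrying two groups, one of them an amino group, can give a lower number than either 4-(dimethylamino)phenyl (an 8.0-fold lower number from compound 3 to compound 4 (0.90 log units; beyond the scatter)) or 4-fluorophenyl (a 52-fold lower number from compound 1 to compound 4 (1.71 log units; beyond the scatter)). It still does not match 4-methylphenyl (a 4.2-fold higher number from compound 2 to compound 4 (0.62 log units; beyond the scatter)). No evidence on hand accounts for these steps. Going by these compounds, the separate contributions of the amino and methoxy groups remain open, and 3-aminophenyl and 4-methoxyphenyl would separate them. On these data alone, whether 3-hydroxy-4-methoxyphenyl or 3-amino-4-methylphenyl would come closer to compound 2 also remains open.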